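Ester to Free Acid at the Chain End of Compound 1

The compounds below may be only part of what the source reports. "The series", "measured", "known", "first", "only" and "open" are said of these compounds alone.

Compound 1 `CCCC(=O)CC/C=C/C=C/C#CC#C/C=C/COC(C)=O` is tested in a functional assay on 518A2 cells (Homo sapiens) for cytotoxicity, read by sulforhodamine B assay, with a stated time of 96 h (on this read-out higher numbers stand for an effect only at larger amounts of compound and lower numbers for an effect already at smaller amounts), where compound 1 gives 9100 nM. Within the data shown here, compound 2 `CCCC(=O)CC/C=C/C=C/C#CC#C/C=C/COC(=O)c1ccccc1` shares the core and in this assay compound 2 gives 20500 nM; the step of a 2.3-fold higher number from compound 1 to compound 2 (0.35 log units; beyond the scatter) stands beyond the scatter, and compound 1 therefore holds the lower of the two numbers known. Compound 3 `CCCC(=O)CC/C=C/C=C/C#CC#C/C=C/C(=O)O` differs from compound 1 in one place: carboxy in place of acetoxymethyl on a double-bonded chain carbon bound to a double-bonded chain carbon. Among the measured compounds shown here, no measured step in this assay changes the ester into a free acid; the only step known, from compound 1 to compound 2, alters the acyl part of the ester and shifts the number modestly. The step to compound 3 is of a different kind, so the expectation rests on thin ground. Compound 3 is expected to give a higher number than compound 1, with a 2.7-fold higher number from compound 1 to compound 3 (0.44 log units; beyond the scatter) estimated, and compound 3 is estimated at 25000 nM within a range from 8000 nM to 80000 nM.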

Compound 3, half-maximal effective concentration: > 30000 nM
Compound 3 was reported as a limit (the forecaster's own chance of this, stated with the estimate: 15%); middle value at least 1.2-fold (0.07 log units) from the limit.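

Up to this point, the only step known at this end of the chain changed the acyl part of the ester and left the ester itself in place. Among these compounds, compound 3 is the first case in which the ester is given up, with carboxy in place of acetoxymethyl on a double-bonded chain carbon bound to a double-bonded chain carbon, and in this assay this change gives an at least 3.2-fold higher number from compound 1 to compound 3 (0.51 log units; beyond the scatter). The result for compound 3 is a limit and not a number, so only a lower bound on the step can be read: the limit of > 30000 nM in this assay, at which 1 of the 3 values shown sits.

The step from 3-acetoxyprop-1-en-1-yl to 2-carboxyethenyl replaces the ester and alters the length of the end group together, and the compounds shown do not separate the two. On these data alone, it remains open how a methyl ester, a primary amide or a hydroxymethyl group at this place would compare with compound 1.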